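Fluoro in Place of Nitro on a Benzyl Ester

A few compounds are considered here, and "the series" means these few. Any claim that something is new, unique, unknown or untested is made for them only; others in the source may bear on it.

Measured so far in an ADME assay on a cell-free system (plasma, Homo sapiens) for metabolic stability; on this read-out lower numbers stand for a shorter-lived compound and higher numbers for a longer-lived compound:
compound 1, `C[C@H](NC(=O)[C@H](N)CCC(=O)OCc1ccc([N+](=O)[O-])cc1)C(=O)O`: 0.113 h
compound 2, `NCCCC[C@H](N)C(=O)OC[C@H]1O[C@@H](n2cc(F)c(=O)[nH]c2=O)C[C@@H]1OC(=O)[C@@H](N)CCCCN`: 0.492 h
compound 3, `Cc1cc(C)nc(N(COC(=O)C(C)(C)C)S(=O)(=O)c2ccc(N)cc2)n1`: 4.07 h

Among these three, compound 1 stands lowest. Compound 2 sits a good way above it, beyond the usual scatter, and compound 3 lies far higher still, the longest-lived of the three by a wide margin. For the measured compounds named here, none of the measured pairs differs in only one place, so the numbers give no direct reading of what a single swap of groups does here.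

Compound 4, `C[C@H](NC(=O)[C@H](N)CCC(=O)OCc1ccc(F)cc1)C(=O)O`, is the untested partner of compound 1. The change is small: fluoro in place of nitro on an aromatic carbon. The benzyl ester and the peptide part of compound 1 are kept unchanged, so the two compounds differ only in that one group. The step is therefore expected to be modest, with a lean towards a somewhat longer half-life, a 1.8-fold higher number from compound 1 to compound 4 (0.25 log units; within the scatter), though it may well stay within the scatter. Compound 4 is estimated to give 0.2 h, in the range from 0.08 h to 0.5 h.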

Compound 4, half-life: 2 h
Beside the measured number, compound 4's estimate is 10-fold (1.00 log units) below it, and the stated range ends below it.
By their numbers in this assay, from the lowest: compound 1; then compound 2; then compound 4; then compound 3.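

In this assay, the swap of nitro for fluoro on an aromatic carbon, para to a large group, gives an 18-fold higher number from compound 1 to compound 4 (1.25 log units; beyond the scatter), a large step. For the compounds shown here, this is the first direct reading of a single change in this set, and it shows that this one place on the benzyl ester can weigh heavily on the half-life, with the peptide part left exactly as it was. Nothing at hand says why the number moves so far.

The compounds shown leave open whether the step belongs to fluoro coming in or to nitro leaving. Plain hydrogen, a methoxy group or a nitrile on the same carbon could help separate the two, and whether the swap carries over to other esters also stays open.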